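This account rests on a few compounds, and the source may have more. Where it says the series, first, only, none or still open, it means among the compounds named here.

Compound 1 `O=C1NCCN1c1ccc(S(=O)(=O)Nc2ccc(I)cc2)cc1`: 260 nM
Compound 2 `CCCCCCCc1ccc(NS(=O)(=O)c2ccc(N3CCNC3=O)cc2)cc1`: > 1000 nM
Compound 3 `COc1ccc(NS(=O)(=O)c2ccc(N3CCNC3=O)cc2)cc1OC`: 340 nM

Of the compounds shown here, three built on the same core have been tested in a functional assay on M21 cells (Homo sapiens) for antiproliferative activity, read by sulforhodamine B assay, with a stated time of 48 h; a lower number here means a stronger inhibitor, a higher number a weaker inhibitor. Compound 1 gives 260 nM, the lowest of the two numbers shown. Compound 3 gives 340 nM, which lies within the scatter of compound 1, so the two cannot be ranked. Compound 2 reaches only the limit of this assay, > 1000 nM, and so gives no number.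

Compound 4 `O=C1NCCN1c1ccc(S(=O)(=O)Nc2cccc(Cl)c2)cc1` has not yet been measured. It differs from compound 1 in one place: 3-chlorophenyl in place of 4-iodophenyl on a sulfonamide nitrogen. Going by the values given here, only one measured step alters this same aryl group: an at least 3.8-fold higher number from compound 1 to compound 2 (0.58 log units; beyond the scatter), a weakening whose full size is hidden because of the limit of > 1000 nM in this assay, at which 1 of the 3 values shown sits. Among the compounds with values here, that step exchanges the halogen for a long heptyl chain; the step to compound 4 keeps a halogen, only a smaller one within a differently named phenyl group, so a smaller loss than seen for compound 2 is expected, yet no measured step shows that 3-chlorophenyl matches 4-iodophenyl. Compound 4 is therefore expected to be a somewhat weaker inhibitor than compound 1, with an estimated step of a 2.3-fold higher number from compound 1 to compound 4 (0.36 log units; beyond the scatter). The estimate for compound 4 in this assay is 600 nM, with a likely range from 200 nM to 2000 nM.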

Compound 4, half-maximal inhibitory concentration: 25 nM
For compound 4 the middle estimate is 24-fold (1.38 log units) above the measured one; measured number outside the range, below it.
By their numbers in this assay, from the lowest: compound 4; then compounds 1 and 3 (each within the scatter of the next). At a limit, above all of these: compound 2.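

The aryl group on the sulfonamide nitrogen can do more than weaken these compounds. In this assay this exchange gives a strong gain: a 10-fold lower number from compound 1 to compound 4 (1.02 log units; beyond the scatter). The group that leaves and the group that enters both hold a single carbon-only aromatic ring and the same count of heavy atoms, and they differ only in the halogen and in how the phenyl group is substituted, so a modest-looking edit at this position can shift the number by a large step. The only earlier step at this position, an at least 3.8-fold higher number from compound 1 to compound 2 (0.58 log units; beyond the scatter), was a loss, and its end point is a limit, not a number: the limit of > 1000 nM in this assay, at which 1 of the 4 values shown sits.

This step changes the halogen and its place on the phenyl ring at once, so the compounds shown cannot tell which of the two carries the gain. They also leave open how this position would respond to a bromophenyl group, or to a phenyl group carrying an amine or a carboxylic acid, and whether any such group could go beyond compound 4.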